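Methoxycarbonyl to ethoxycarbonyl at the limit of the assay

A few compounds are considered here, and "the series" means these few. Any claim that something is new, unique, unknown or untested is made for them only; others in the source may bear on it.

In a functional assay on the whole organism for antagonist activity, with Mus musculus as the target (on this read-out higher numbers stand for an effect only at larger amounts of compound and lower numbers for an effect already at smaller amounts), compound 1 `COC(=O)N(C)C(C)C#CCn1ccnc1` reads > 100 mg/kg as a limit, not a number. Compound 2 `COC(=O)N(C)C(C)C#CCN(C)C` reads > 100 mg/kg as a limit too. The one measured link is a step that the two limits leave unreadable from compound 1 to compound 2 and it lies elsewhere on the molecule, so it offers no size to carry over. Compound 3 `CCOC(=O)N(C)C(C)C#CCn1ccnc1` carries methyl in place of hydrogen on a saturated chain carbon bound to an oxygen next to a carbonyl group and so turns methoxycarbonyl to ethoxycarbonyl. With only the limit of > 100 mg/kg in this assay, at which 2 of the 2 values shown sit, to go on, no shift beyond the scatter is expected in this assay and the estimated step that the limit leaves unreadable from compound 1 to compound 3 has no firm direction. Compound 3 is expected at 150 mg/kg within an estimated range from 60 mg/kg to 400 mg/kg and may well come out only as a limit again.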

Compound 3, dose for half-maximal effect: > 100 mg/kg
Compound 3: only a limit was reported; the forecaster's own chance of this, stated with the estimate: 75%; the middle value lies beyond the limit too.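

Compound 1 and compound 3 both give only a limit, so no step between them can be read: the limit of > 100 mg/kg in this assay, at which 3 of the 3 values shown sit.

The compounds shown leave open whether methoxycarbonyl and ethoxycarbonyl differ at all in this assay; none of them gives an actual number there.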